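The source may report more compounds than this note shows. Statements on the series, on what has been measured and on what is new or still open speak of the compounds shown alone.

Working notes on the series. The shared core is that of compound 1 `COc1cc2c(cc1OC)C(CC(=O)O)CC2`; compound 2 `CCN(CC)C(=O)CC1CCc2cc(OC)c(OC)cc21` and compound 3 `COc1cc2c(cc1OC)C(CC(=O)N1CCCC1)CC2` vary only the group on the carbonyl carbon. In a functional assay on the whole organism (strain Wistar) for inhibition, with Rattus norvegicus as the target, read by paw edema, with stated times of 60 min and 2 h, at a dose of 100 mg/kg by the oral route (on this read-out higher numbers stand for more inhibition at the one dose given (going by the name of the read-out) and lower numbers for less inhibition), compound 1 gives 24%, compound 2 gives 40% and compound 3 gives 20%. Compound 3 thus holds the lowest of the three numbers, though the step of a number 4 percentage points lower from compound 1 to compound 3 (within the scatter) leaves it within the scatter of compound 1, while the step of a number 20 percentage points lower from compound 2 to compound 3 (beyond the scatter) lies beyond it. The step of a number 16 percentage points higher from compound 1 to compound 2 (beyond the scatter) completes the picture: the three carbonyl substituents span a modest range.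

Compound 4 `COc1cc2c(cc1OC)C(CC(=O)NCCO)CC2` differs from compound 3 as follows: (2-hydroxyethyl)amino in place of pyrrolidin-1-yl on a carbonyl carbon. For the measured compounds named here, no measured step exchanges pyrrolidin-1-yl for a (2-hydroxyethyl)amino group, or any tertiary amide for a secondary one, so no direct guide exists. Going by the values given here, the steps between hydroxy, diethylamino and pyrrolidin-1-yl, at most modest in size, are the only bearing evidence, and they do not single out a direction for this change. The expected step of a number 5 percentage points higher from compound 3 to compound 4 (within the scatter) is therefore estimated as one not beyond the scatter, with wide uncertainty. For compound 4 in this assay the estimate is 25%, ranging from 8% to 45%.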

Compound 4, a percentage reported as inhibition, in the whole organism at one dose (the size of the read-out at that dose, not a potency): 0%
Beside the measured number, compound 4's estimate is 25 percentage points above it, and the stated range ends above it.
By their numbers in this assay, from the lowest: compound 4; then compounds 3 and 1 (each within the scatter of the next); then compound 2.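

In this assay, for the compounds shown here, compound 4 gives 0%, the lowest number of the four, and the carbonyl position now shows a larger spread than the earlier compounds revealed: the series contains a number 20 percentage points lower from compound 3 to compound 4 (beyond the scatter), a number 24 percentage points lower from compound 1 to compound 4 (beyond the scatter) and its first large step, a number 40 percentage points lower from compound 2 to compound 4 (beyond the scatter). Replacing hydroxy with an amine-derived group also no longer has one outcome, since a number 16 percentage points higher from compound 1 to compound 2 (beyond the scatter) stands against the fall to compound 4, while compound 3 remains within the scatter of compound 1, so the result depends on which group enters and not merely on the change from acid to amide. No measurement in hand accounts for the fall at compound 4.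

The compounds shown leave open whether the result follows the terminal hydroxyl of the (2-hydroxyethyl)amino group or the amide hydrogen, a question that an ethylamino group on the same carbonyl carbon would address. A (2-methoxyethyl)amino group or a morpholin-4-yl group would likewise test the oxygen-bearing chain in other forms, one retaining the amide hydrogen and the other lacking it.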